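The source may report more compounds than this note shows. Statements on the series, on what has been measured and on what is new or still open speak of the compounds shown alone.

Measured compounds:
- compound 1, `C=CC(=O)Nc1cccc(NC(=O)CSc2nc(Nc3ccccc3Cl)c3ccccc3n2)c1`: 10000 nM
- compound 2, `C=CC(=O)Nc1cccc(NC(=O)CSc2nc(Nc3cccc(Br)c3)c3ccccc3n2)c1`: 12100 nM

In a functional assay on NCI-H1975 cells (Homo sapiens) for inhibition, read by MTT assay, with a stated time of 72 h (on this read-out higher numbers stand for weaker inhibition and lower numbers for stronger inhibition), compound 2 gives 12100 nM, the highest of the two numbers, and compound 1 is its nearest neighbour. Among the compounds with values here, the only measured step, a 1.2-fold higher number from compound 1 to compound 2 (0.08 log units; within the scatter), shows that swapping one halogen-bearing phenyl for another on the same nitrogen left the read-out essentially unchanged. Compound 3, `C=CC(=O)Nc1cccc(NC(=O)CSc2nc(Nc3cccc([N+](=O)[O-])c3)c3ccccc3n2)c1`, differs from compound 2 as follows: nitro in place of bromo on an aromatic carbon. Within the data shown here, no measured pair shows a nitro group entering at this position, so the single step offers only indirect guidance: a change of the substituent on this ring did not move the number beyond the scatter. On that basis no step beyond the scatter in this assay is expected. Compound 3 is estimated at 12000 nM, with a likely range from 4000 nM to 36000 nM. This estimate means a 1.0-fold lower number from compound 2 to compound 3 (0.00 log units; within the scatter).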

Compound 3, half-maximal inhibitory concentration: 22600 nM
For compound 3 the middle estimate is 1.9-fold (0.27 log units) below the measured one; the measured number falls inside the stated range.
By their numbers in this assay, from the lowest: compounds 1, 2 and 3 (each within the scatter of the next, the first and the last beyond it).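

In this assay, putting nitro in place of bromo on the aromatic carbon gives a 1.9-fold higher number from compound 2 to compound 3 (0.27 log units; within the scatter), so even a group that brings in hydrogen-bond acceptors, where bromo has none, does not move the number past the usual scatter. Against the 2-chlorophenyl, however, the 3-nitrophenyl gives a 2.3-fold higher number from compound 1 to compound 3 (0.35 log units; beyond the scatter), a modest step and the first in this set beyond the scatter, in the direction of weaker inhibition. Nothing available here explains either step.

As far as these compounds go, all three compounds carry a single electron-rich or halogen-type label only in the loosest sense, so it remains open whether an amine or a carboxylic acid on this ring would behave differently. Also open, from the compounds shown here alone, is whether any group here can bring the number well below that of compound 1, 10000 nM.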